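This account rests on a few compounds, and the source may have more. Where it says the series, first, only, none or still open, it means among the compounds named here.

Measured so far:
- compound 1 `COC(=O)[C@@]1(C)CC[C@@H]2C3=C1CC[C@@H](C)[C@]3(C)C[C@@H]1c3ccccc3N[C@H]21` — 78000 nM
- compound 2 `COC(=O)[C@@]1(C)CC[C@@H]2C3=C1CC[C@@H](C)[C@]3(C)C[C@@H]1c3cc(F)ccc3N[C@H]21` — 18000 nM

Of the two numbers in a functional assay on HBL-100 cells (Homo sapiens) for inhibition, read by sulforhodamine B assay, with a stated time of 48 h (a lower number here means a stronger inhibitor of growth, a higher number a weaker inhibitor of growth), compound 1 holds the highest, so it is the weaker growth inhibitor of the pair. Its nearest neighbour is compound 2, and the step of a 4.3-fold lower number from compound 1 to compound 2 (0.64 log units; beyond the scatter) is a modest gain that goes beyond the scatter.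

Compound 3 `COC(=O)[C@@]1(C)CC[C@@H]2C3=C1CC[C@@H](C)[C@]3(C)C[C@@H]1c3cccc(C)c3N[C@H]21` shares the core of compound 1 and differs from it in one place: methyl in place of hydrogen on an aromatic carbon. The added group is one carbon, bearing no donor or acceptor, on the six-membered ring of carbon only, ortho to a fused ring and meta to a fused ring.

Going by the values given here, only one measured step bears on this change, the fluoro step from compound 1 to compound 2. It shows that a single small substituent on this ring can shift the number, but it is a different group in a different position, so it gives no direct guide for the methyl. A small move in either direction, possibly within the scatter, is expected here.

For compound 3 in this assay a value of 50000 nM is estimated, with a range from 15000 nM to 160000 nM, meaning an expected step of a 1.6-fold lower number from compound 1 to compound 3 (0.19 log units; within the scatter).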

Compound 3, concentration for 50% growth inhibition: 32000 nM
For compound 3 the middle estimate is 1.6-fold (0.19 log units) above the measured one, and the stated range covers the measured number.
By their numbers in this assay, from the lowest: compounds 2 and 3 (each within the scatter of the next); then compound 1.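

Putting methyl on this aromatic carbon, ortho to a fused ring and meta to a fused ring, moves the number in this assay by a modest amount that goes beyond the scatter (a 2.4-fold lower number from compound 1 to compound 3 (0.39 log units; beyond the scatter)). Until now, only the fluoro change (a 4.3-fold lower number from compound 1 to compound 2 (0.64 log units; beyond the scatter)) had shown an effect, so this result adds a second small group on the same aromatic ring, at a different carbon, that also lowers the number relative to compound 1. No separate measurement bears on why either change has this effect.

The compounds shown leave open whether the gain depends more on the group or on the carbon that carries it, since methyl and fluoro have not been compared at one shared position. They also leave open how far this carbon tolerates change, for example whether a longer chain such as ethyl, a chlorine atom, a methoxy group, an amine or a carboxylic acid placed there would lower the number further, leave it unchanged or raise it again.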